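A few compounds are considered here, and "the series" means these few. Any claim that something is new, unique, unknown or untested is made for them only; others in the source may bear on it.

Working notes on the series. The shared core carries an acylguanidine and a methylsulfonyl group; the compounds differ only in the substituent on one aromatic carbon. In a functional assay for inhibition of sodium/hydrogen exchanger (Oryctolagus cuniculus) (a higher number here means a weaker inhibitor, a lower number a stronger inhibitor), compound 1 `Cc1cc(-c2ccc(F)cc2)c(S(C)(=O)=O)cc1C(=O)N=C(N)N` gives 36 nM, compound 2 `CCCSc1cc(C)c(C(=O)N=C(N)N)cc1S(C)(=O)=O` gives 6.8 nM and compound 3 `Cc1cc(SC(C)C)c(S(C)(=O)=O)cc1C(=O)N=C(N)N` gives 12 nM. Compound 3 thus stands second highest of the three numbers: one step is a 1.8-fold higher number from compound 2 to compound 3 (0.25 log units; within the scatter), which is within the scatter, while the other is a 3.0-fold lower number from compound 1 to compound 3 (0.48 log units; beyond the scatter), which is beyond it.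

Compound 4 `Cc1cc(N2CCCC2)c(S(C)(=O)=O)cc1C(=O)N=C(N)N` is unmeasured. Change: pyrrolidin-1-yl in place of isopropylsulfanyl on an aromatic carbon. Among the measured compounds shown here, the steps that bear on this position are a 5.3-fold lower number from compound 1 to compound 2 (0.72 log units; beyond the scatter) and a 3.0-fold lower number from compound 1 to compound 3 (0.48 log units; beyond the scatter), both modest drops on leaving the aryl group; between the two chains the step is a 1.8-fold higher number from compound 2 to compound 3 (0.25 log units; within the scatter), within the scatter. Nothing measured covers a ring amine at this carbon, so the expectation rests on the similar size of the group entering, and the step from compound 3 is expected to be no change at the digits printed from compound 3 to compound 4 (within the scatter), none beyond the scatter. In this assay compound 4 is expected at 12 nM, range 4 nM to 40 nM.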

Compound 4, half-maximal inhibitory concentration: 11 nM
Estimate against measurement, compound 4: 1.1-fold (0.04 log units) above, and the stated range covers the measured number.
By their numbers in this assay, from the lowest: compounds 2, 4 and 3 (each within the scatter of the next); then compound 1.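

At this carbon, para to a group of 6 heavy atoms, a ring attached through nitrogen reads the same in this assay as the two sulfur-linked chains: a 1.1-fold lower number from compound 3 to compound 4 (0.04 log units; within the scatter) and a 1.6-fold higher number from compound 2 to compound 4 (0.21 log units; within the scatter) are both within the scatter. The group at this carbon can therefore carry a nitrogen instead of a sulfur, and a five-membered non-aromatic ring instead of an open chain, while the number stays with those of the chains and apart from the 4-fluorophenyl compound, with a 3.3-fold lower number from compound 1 to compound 4 (0.51 log units; beyond the scatter) beyond the scatter. No measurement at hand accounts for this result.

Open, from the compounds shown here alone, is whether a larger ring amine such as piperidin-1-yl or morpholin-4-yl, or an open-chain amine such as dimethylamino, would stay in the same range. Also open, going by these compounds, is whether an unsubstituted phenyl would read like the 4-fluorophenyl compound.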